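The source may report more compounds than this note shows. Statements on the series, on what has been measured and on what is new or still open speak of the compounds shown alone.

In a functional assay on MIA PaCa-2 cells (Homo sapiens) for inhibition, read by MTT assay, with a stated time of 72 h (on this read-out higher numbers stand for weaker inhibition of growth and lower numbers for stronger inhibition of growth), three compounds that share one core have been measured so far. Compound 1 `O=S(=O)(NCCCNCc1ccc(Cl)cc1)c1cc(C(F)(F)F)cc(C(F)(F)F)c1` gives 2800 nM. Compound 2 `O=S(=O)(NCCCNCc1cccc(Cl)c1)c1cc(C(F)(F)F)cc(C(F)(F)F)c1` gives 4400 nM. Compound 3 `O=S(=O)(NCCCNCc1ccc(-c2ccccc2)cc1)c1cc(C(F)(F)F)cc(C(F)(F)F)c1` gives 2400 nM, the lowest of the three numbers, but its gap to compound 1 and its gap to compound 2 both lie within the scatter, so the three cannot be ranked. Compound 4 `O=S(=O)(NCCCNCc1ccc(Br)cc1)c1cc(C(F)(F)F)cc(C(F)(F)F)c1` has not yet been measured. It differs from compound 3 in a single place: bromo in place of phenyl on an aromatic carbon. The measured step that bears on this is the one in which phenyl took the place of chloro, a 1.2-fold lower number from compound 1 to compound 3 (0.07 log units; within the scatter), which stayed within the scatter. Among the compounds with values here, no measured step involves bromo, so the closest guide is that swap between chloro and phenyl. For compound 4 the expected step is therefore a 1.2-fold higher number from compound 3 to compound 4 (0.07 log units; within the scatter), because the earlier swap a 1.2-fold lower number from compound 1 to compound 3 (0.07 log units; within the scatter) did not move the number beyond the scatter. Compound 4 is thus estimated at 2800 nM, with a range from 1400 nM to 5600 nM.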

Compound 4, concentration for 50% growth inhibition: 2300 nM
Beside the measured number, compound 4's estimate is 1.2-fold (0.09 log units) above it; low and high end bracket the measured number.
By their numbers in this assay, from the lowest: compounds 4, 3, 1 and 2 (each within the scatter of the next).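

In this assay, the aromatic carbon para to a large group has now carried three different groups with no step beyond the scatter: bromo in place of phenyl gives a 1.0-fold lower number from compound 3 to compound 4 (0.02 log units; within the scatter), and bromo in place of chloro gives a 1.2-fold lower number from compound 1 to compound 4 (0.09 log units; within the scatter), so a single bromine atom and a whole phenyl ring of six heavy atoms cannot be told apart here. The 4-bromophenyl in place of 3-chlorophenyl gives a 1.9-fold lower number from compound 2 to compound 4 (0.28 log units; within the scatter), which also stays within the scatter, so this change does not separate the two either. No measurement available here explains these results.

From the compounds shown here alone, it remains open whether an amine or a carboxylic acid on this aromatic carbon would move the number beyond the scatter. Going by these compounds, it is equally open whether a longer chain in the shared core would do so.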